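The source may report more compounds than this note shows. Statements on the series, on what has been measured and on what is new or still open speak of the compounds shown alone.

Compound 1 `CCc1nc(-c2ccc(Cl)cc2Cl)c(CC)nc1NC(COC)COC` and compound 2 `CCc1nc(N(CC2CC2)CC2CC2)c(CC)nc1-c1ccc(Cl)cc1Cl` differ in one group on the shared core. In an in vitro ADME assay on microsomes (Rattus norvegicus) for metabolic stability (on this read-out lower numbers stand for a shorter-lived compound and higher numbers for a longer-lived compound), compound 1 gives 0.0417 h. Compound 2 gives < 0.0167 h, which is a limit of the assay and not a number. For the measured compounds named here, the single measured step, an at least 2.4-fold lower number from compound 1 to compound 2 (0.39 log units; beyond the scatter), is the only guide available. Compound 3 `CCc1nc(-c2ccc(Cl)cc2Cl)c(CC)nc1NC(C)CN(C)C` changes that same place: (1-((dimethylamino)methyl)ethyl)amino in place of bis(cyclopropylmethyl)amino on an aromatic carbon. The entering (1-((dimethylamino)methyl)ethyl)amino is an open chain, closer in outline to the (2-methoxy-1-(methoxymethyl)ethyl)amino of compound 1 than to the leaving group. The value of compound 1, 0.0417 h, therefore anchors the expectation, and the measured step is expected to be largely undone. The expected change is an at least 2.9-fold higher number from compound 2 to compound 3 (0.47 log units; beyond the scatter), an upward step. For compound 3 the estimate is 0.05 h, with an expected range from 0.02 h to 0.12 h.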

Compound 3, half-life: < 0.0167 h
Compound 3 gave a limit, no number (the forecaster's own chance of this, stated with the estimate: 20%); middle value at least 2.9-fold (0.47 log units) from the limit.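

In this assay, putting 1-((dimethylamino)methyl)ethyl in place of 2-methoxy-1-(methoxymethyl)ethyl on the nitrogen gives an at least 2.4-fold lower number from compound 1 to compound 3 (0.39 log units; beyond the scatter). This shows that an open chain at this position is not enough to keep the number of compound 1, and that what the chain carries makes a difference. The step between compound 2 and compound 3 cannot be read because both stand at a limit and not at a number: the limit of < 0.0167 h in this assay, at which 2 of the 3 values shown sit.

On these data alone, how far compound 2 and compound 3 really lie apart stays open, as does which part of the chain of compound 1 goes with its higher number. Also open, as far as these compounds go, is whether a chain ending in a hydroxyl group or a carboxylic acid at this place would clear the limit as compound 1 does.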